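Extending the amide chain: from propanoyl to propylcarbonyl

The compounds below may be only part of what the source reports. "The series", "measured", "known", "first", "only" and "open" are said of these compounds alone.

Measured compounds:
Compound 1 `COc1ccc(F)c(CNC(C)=O)c1`: 1950 nM
Compound 2 `COc1ccc(CNC(C)=O)cc1F`: 1510 nM
Compound 3 `CCC(=O)NCc1ccc(OC)c(F)c1`: 1050 nM

In an assay on isolated protein for agonist activity at melatonin receptor type 1C (Xenopus laevis), read by spectrophotometry (on this read-out higher numbers stand for an effect only at larger amounts of compound and lower numbers for an effect already at smaller amounts), compound 3 gives 1050 nM, the lowest of the three numbers. Its nearest neighbour is compound 2, and the gap between the two lies within the scatter, as does the gap to compound 1, so no order among the three can be claimed.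

Compound 4 `CCCC(=O)NCc1ccc(OC)c(F)c1` differs from compound 3 by methyl in place of hydrogen on a saturated chain carbon, two bonds along the chain from a carbonyl carbon, the chain growing from propanoyl to propylcarbonyl. For the measured compounds named here, the one measured step that bears on this is the earlier lengthening of the same chain, a 1.4-fold lower number from compound 2 to compound 3 (0.16 log units; within the scatter), which did not leave the scatter. Going by the values given here, a second carbon added one bond further out is therefore expected to move the number little, if at all, with no direction that can be stated with confidence; a small drift toward lower numbers would be the most that the one comparable step supports.

For compound 4 in this assay the estimate is 800 nM, with a range from 350 nM to 1800 nM. This corresponds to an expected step of a 1.3-fold lower number from compound 3 to compound 4 (0.12 log units; within the scatter).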

Compound 4, half-maximal effective concentration: 661 nM
Compound 4: the middle estimate sits 1.2-fold (0.08 log units) above what was measured; low and high end bracket the measured number.
By their numbers in this assay, from the lowest: compounds 4, 3, 2 and 1 (each within the scatter of the next, the first and the last beyond it).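

Taken alone, the added methyl stays small in this assay (a 1.6-fold lower number from compound 3 to compound 4 (0.20 log units; within the scatter)). Read as a whole, however, the ethyl in place of hydrogen on the saturated chain carbon bound to the carbonyl carbon gives a modest change that passes beyond the scatter (a 2.3-fold lower number from compound 2 to compound 4 (0.36 log units; beyond the scatter)), so this position of the chain does register a change once the full difference is taken, though compound 3 cannot be separated from either neighbour. No measurement is at hand that bears on what lies behind this.

From the compounds shown here alone, whether a longer chain, a branched isopropyl group or a cyclopropyl ring on the carbonyl would carry the trend further, or reverse it, remains open. Also open, going by these compounds, is whether the same chain growth on the core of compound 1 would give a comparable change.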